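From 2-methylphenyl to 3-(trifluoromethyl)phenyl on the shared core

This account rests on a few compounds, and the source may have more. Where it says the series, first, only, none or still open, it means among the compounds named here.

Compound 1 `CCNC(=O)c1cc(Oc2ccc(NC(=O)c3nn(-c4ccccc4C)c(=O)cc3C)cc2)ccn1` gives 34800 nM
Compound 2 `CCCNC(=O)c1cc(Oc2ccc(NC(=O)c3nn(-c4cccc(C(F)(F)F)c4)c(=O)cc3C)cc2F)ccn1` gives 9240 nM

In a functional assay on A549 cells (Homo sapiens) for antiproliferative activity, read by MTT assay, with a stated time of 72 h (a higher number here means a weaker inhibitor, a lower number a stronger inhibitor), compound 1 holds the higher of the two numbers at 34800 nM, and compound 2 gives 9240 nM. The gap between these two compounds lies beyond the scatter. Compound 3 `CCNC(=O)c1cc(Oc2ccc(NC(=O)c3nn(-c4cccc(C(F)(F)F)c4)c(=O)cc3C)cc2)ccn1` carries 3-(trifluoromethyl)phenyl in place of 2-methylphenyl on an aromatic nitrogen. Among the measured compounds shown here, no measured step isolates this change. Compound 2 also holds 3-(trifluoromethyl)phenyl and gives 9240 nM here, so a moderately lower number is expected, with a 2.2-fold lower number from compound 1 to compound 3 (0.34 log units; beyond the scatter) as the estimated step. For compound 3 the estimated value is 16000 nM within an expected range of 6000 nM to 42000 nM for repeat measurements.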

Compound 3, half-maximal inhibitory concentration: 10000 nM
For compound 3 the middle estimate is 1.6-fold (0.20 log units) above the measured one; measured number inside the range.
By their numbers in this assay, from the lowest: compounds 2 and 3 (each within the scatter of the next); then compound 1.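

Replacing 2-methylphenyl with 3-(trifluoromethyl)phenyl on the aromatic nitrogen gives a 3.5-fold lower number from compound 1 to compound 3 (0.54 log units; beyond the scatter) in this assay, with the rest of the core of compound 1 unchanged. This shows that the number responds to the aryl group at this position, which the first two compounds could not show because they differ in more than one place. Nothing available explains the size of this step. Still open, on these data alone, is how a 3-methylphenyl or an unsubstituted phenyl would compare on the same nitrogen. The step also cannot separate the change of group from the change in where it sits on the phenyl ring.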